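The source may report more compounds than this note shows. Statements on the series, on what has been measured and on what is new or still open speak of the compounds shown alone.

In an ADME assay on THP-1 cells (Homo sapiens) for cytotoxicity, read by MTT assay (a lower number here means that less compound is tolerated, a higher number that more compound is tolerated), compound 1 (`COc1ccc(C(=O)/C=C/c2ccc(OC)c(OC)c2)c(O)c1`) reads > 100000 nM, and this is a limit of the assay, not a number. Compound 2 (`COc1ccc(C(=O)/C=C/c2cc(OC)c(OC)c(OC)c2)c(O)c1`) reads > 100000 nM, and this is also a limit. The two measured compounds therefore share one position (the limit of > 100000 nM in this assay, at which 2 of the 2 values shown sit). Within the data shown here, the only measured step, methoxy in place of hydrogen on an aromatic carbon, gives no size that can be carried over (a step that the two limits leave unreadable from compound 1 to compound 2).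

Compound 3 (`COc1cccc(/C=C/C(=O)c2ccc(OC)cc2O)c1`) has not yet been measured. Its structure departs from compound 1 by hydrogen in place of methoxy on an aromatic carbon, ortho to a methoxy group and para to a large group (hydrogen in place of methoxy on an aromatic carbon). This runs in the reverse sense to the measured step, but on another ring position, and the series holds no numerical value to calibrate it. With compound 1 and compound 2 both at the limit (the limit of > 100000 nM in this assay, at which 2 of the 2 values shown sit), no step beyond the scatter is expected in this assay, in either direction, and another limit is the likely report. The estimated step is small (a number no higher from compound 1 to compound 3 (the limit leaves the size open)). For compound 3 the expected value is 100000 nM, with an estimated range from 50000 nM to 200000 nM.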

Compound 3, half-maximal cytotoxic concentration: > 25000 nM
Compound 3: no number, only a limit; the forecaster's own chance of this, stated with the estimate: 85%; the middle value is on the limit's open side.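

In this assay compound 3 gives > 25000 nM, a limit of the assay and not a number. Compound 1 gives > 100000 nM, also a limit. Among these compounds, no step between compound 1 and compound 3 can be read from these two limits. The compounds shown leave open what numerical value compound 1, compound 2 or compound 3 would take in this assay, and whether either methoxy change shifts it.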